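A few compounds are considered here, and "the series" means these few. Any claim that something is new, unique, unknown or untested is made for them only; others in the source may bear on it.

Compound 1 `CCCNC(=O)c1ccc(Oc2nc(-c3c(C)noc3C)cnc2N)cc1` — a functional assay on HepG2 cells (Homo sapiens) for inhibition, read by MTT assay, with a stated time of 72 h; a higher number here means a weaker inhibitor, a lower number a stronger inhibitor: 6880 nM
Compound 2 `Cc1noc(C)c1-c1cnc(N)c(Oc2ccc(C(=O)Nc3ccc(Cl)cn3)cc2)n1` — this assay: 35600 nM

Compound 2 stands at the higher of the two numbers, the weaker inhibitor of the pair; the gap is a 5.2-fold higher number from compound 1 to compound 2 (0.71 log units; beyond the scatter). Compound 3 `Cn1cc(-c2cnc(N)c(Oc3ccc(C(=O)Nc4ccc(Cl)cn4)cc3)n2)cn1` differs from compound 2 only by 1-methyl-1H-pyrazol-4-yl in place of 3,5-dimethyl-1,2-oxazol-4-yl on an aromatic carbon. Among the measured compounds shown here, no measured step touches this position: the single measured step, a 5.2-fold higher number from compound 1 to compound 2 (0.71 log units; beyond the scatter), concerns the amide nitrogen and says nothing about the aromatic carbon exchange. In the absence of bearing data the expected step is a 1.0-fold lower number from compound 2 to compound 3 (0.01 log units; within the scatter), none beyond the scatter. Compound 3 is expected near 35000 nM, between 9000 nM and 130000 nM.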

Compound 3, half-maximal inhibitory concentration: 24200 nM
Beside the measured number, compound 3's estimate is 1.4-fold (0.16 log units) above it, within the range that was stated.
By their numbers in this assay, from the lowest: compound 1; then compounds 3 and 2 (each within the scatter of the next).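

Working notes on the position para to an amino group: 1-methyl-1H-pyrazol-4-yl in place of 3,5-dimethyl-1,2-oxazol-4-yl gives a 1.5-fold lower number from compound 2 to compound 3 (0.17 log units; within the scatter) in this assay, the first reading at this aromatic carbon. With the 5-chloropyridin-2-yl amide held fixed, this exchange of one five-membered aromatic ring for another cannot be told from scatter. Nothing available accounts for the result.

As far as these compounds go, whether the same exchange behaves alike on the propyl amide of compound 1 remains open. Also open, from the compounds shown here alone, is whether a different group here, such as a phenyl ring or an amine, would move the number beyond the scatter.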